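Bromo terminus replaced by a carboxyhexyl chain

The source may hold more compounds than are shown below. What is called first, only, known or untested is meant among the compounds shown, and "the series" means these compounds.

Working notes on the series sharing the core of compound 1 `O=c1c(-c2ccc(O)cc2)coc2cc(OCCCBr)ccc12`. In an assay on isolated protein (Cricetulus griseus) for inhibition of Monoamine oxidase (Homo sapiens) (on this read-out lower numbers stand for stronger inhibition and higher numbers for weaker inhibition), compound 1 gives 150 nM, the lowest of the three numbers in hand. Compound 2 `O=c1c(-c2ccc(O)cc2)coc2cc(OCC(O)CO)ccc12` gives 1700 nM and compound 3 `C=CCOc1ccc2c(=O)c(-c3ccc(O)cc3)coc2c1` gives 450 nM; the steps of an 11-fold higher number from compound 1 to compound 2 (1.05 log units; beyond the scatter) and a 3.0-fold higher number from compound 1 to compound 3 (0.48 log units; beyond the scatter) both run to higher numbers from compound 1, and a 3.8-fold lower number from compound 2 to compound 3 (0.58 log units; beyond the scatter) runs the other way.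

Compound 4 `O=C(O)CCCCCCCCCOc1ccc2c(=O)c(-c3ccc(O)cc3)coc2c1` differs from compound 1 as follows: 6-carboxyhexyl in place of bromo on a saturated chain carbon, three bonds along the chain from an oxygen on an aromatic ring. The two measured steps that change the end of the same chain, namely an 11-fold higher number from compound 1 to compound 2 (1.05 log units; beyond the scatter) and a 3.0-fold higher number from compound 1 to compound 3 (0.48 log units; beyond the scatter), both raised the number; the larger of them, to compound 2, brought in hydrogen-bond donor and acceptor as the change to compound 4 also does. Among the compounds with values here, a rise beyond the scatter in this assay is therefore expected, of a size between those two steps, though no measured compound carries a chain of this length, so the range is kept wide. For compound 4 the expected step is a 5.3-fold higher number from compound 1 to compound 4 (0.73 log units; beyond the scatter), giving an estimate of 800 nM with a range from 250 nM to 3000 nM.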

Compound 4, half-maximal inhibitory concentration: 10000 nM
Compound 4: middle estimate off by 13-fold (1.10 log units), on the low side, and the stated range ends below it.
By their numbers in this assay, from the lowest: compound 1; then compound 3; then compound 2; then compound 4.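

At this chain end, 6-carboxyhexyl in place of bromo gives a 67-fold higher number from compound 1 to compound 4 (1.82 log units; beyond the scatter), a larger rise than an 11-fold higher number from compound 1 to compound 2 (1.05 log units; beyond the scatter), and compound 4 now has the highest number of the four in this assay. Within the data shown here, the position is therefore more sensitive than the earlier compounds showed: all changes here so far raise the number from compound 1, and the span of that rise is now much wider. No evidence bears on why this change costs so much.

The step alters chain length and the terminal group at once, so the compounds shown cannot separate the two. A plain alkyl chain ending in a methyl group, or a methyl ester or an amine at the end of the longer chain, would show which of them carries the rise.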